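The source may hold more compounds than are shown below. What is called first, only, known or untested is meant among the compounds shown, and "the series" means these compounds.

Measured so far in a functional assay on WM 266-4 cells (Homo sapiens) for antiproliferative activity, read by MTT assay, with a stated time of 48 h; on this read-out lower numbers stand for stronger inhibition of growth and higher numbers for weaker inhibition of growth:
- Compound 1 `S=C(Nc1ccccc1)N1N=C(c2ccc(Cl)cc2)CC1c1ccc2c(c1)OCCO2`: > 200000 nM, a limit of the assay and not a number.
- Compound 2 `Cc1ccc(C2=NN(C(=S)Nc3ccccc3)C(c3ccc4c(c3)OCCO4)C2)cc1`: 10300 nM.

Among the compounds with values here, compound 2 therefore holds the only actual number in this assay. Compound 3 `S=C(Nc1ccccc1)N1N=C(c2ccc(OCc3ccccc3)cc2)CC1c1ccc2c(c1)OCCO2` differs from it as follows: benzyloxy in place of methyl on an aromatic carbon. Within the data shown here, one measured step bears on this carbon, the large at least 19-fold lower number from compound 1 to compound 2 (1.28 log units; beyond the scatter). It shows that the substituent here can matter, but it involves neither a benzyloxy group nor a direction for one. A step beyond the scatter is therefore not expected, though confidence is low. The expected step is a 1.4-fold higher number from compound 2 to compound 3 (0.13 log units; within the scatter). For compound 3 the estimated value is 14000 nM, with an expected range of 2500 nM to 80000 nM.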

Compound 3, concentration for 50% growth inhibition: 420 nM
The estimate for compound 3 lay 33-fold (1.52 log units) above the measured number; measured number below the stated range.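

Benzyloxy in place of methyl on this aromatic carbon, para to a large group, gives a 25-fold lower number from compound 2 to compound 3 (1.39 log units; beyond the scatter) in this assay. The earlier compounds shown here carried only a single-atom chloro or a methyl here, and this much larger group now goes with stronger inhibition of growth. Benzyloxy in place of chloro gives an at least 470-fold lower number from compound 1 to compound 3 (2.67 log units; beyond the scatter); that step starts from a limit of the assay for compound 1, not from a number.

Whether the added aromatic ring, the ether oxygen or the length of the group accounts for this stays open. So does the outcome with a methoxy group, a directly attached phenyl ring or a longer alkoxy chain at this carbon.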